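Removing a Methoxy from a Dimethoxyphenyl Triazole Oxime

The source may report more compounds than this note shows. Statements on the series, on what has been measured and on what is new or still open speak of the compounds shown alone.

The measured compounds and their values:
compound 1, `C=CCn1c(SCC(=O)c2ccccc2)nnc1-c1ccccc1`, 58%
compound 2, `C=CCn1c(SCC(=O)c2ccccc2)nnc1-c1ccc(OC)cc1`, 53%
compound 3, `CCn1c(SC/C(=N/O)c2ccccc2)nnc1-c1ccc(OC)c(OC)c1`, 67%

All three were tested in a functional assay on the whole organism (strain albino) for inhibition, with Rattus norvegicus as the target, read by paw edema, with a stated time of 2 h, at a dose of 0.28 mmol/kg by the oral route; on this read-out higher numbers stand for more inhibition at the one dose given (going by the name of the read-out) and lower numbers for less inhibition. Compound 3 gives the highest of the three numbers, though its gap to compound 1 lies within the scatter and only its gap to compound 2 lies beyond it. The difference between the cores of compound 3 and compound 2 is not broken down here.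

One change is seen once among the measured pairs: hydrogen in place of methoxy on an aromatic carbon, which made a number 5 percentage points higher from compound 2 to compound 1 (within the scatter). The unmeasured compound 4, `CCn1c(SC/C(=N/O)c2ccccc2)nnc1-c1ccc(OC)cc1`, arises from compound 3 by hydrogen in place of methoxy on an aromatic carbon. This is the same kind of change as from compound 2 to compound 1, but not the same: in compound 1 the hydrogen enters para to a large group, whereas in compound 4 it enters ortho to a methoxy group and meta to a large group.

Because the earlier step was a number 5 percentage points higher from compound 2 to compound 1 (within the scatter), compound 4 is expected to lie close to compound 3, with an estimated step of a number 1 percentage points lower from compound 3 to compound 4 (within the scatter). The estimate for compound 4 is 66%, between 54% and 77%.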

Compound 4, a percentage reported as inhibition, in the whole organism at one dose (the size of the read-out at that dose, not a potency): 72%
Beside the measured number, compound 4's estimate is 6 percentage points below it; measured number inside the range.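

In this assay, hydrogen in place of methoxy on an aromatic carbon gave a number 5 percentage points higher from compound 3 to compound 4 (within the scatter). Set beside the earlier case, the change reads the same on both cores: the same change on two cores in this assay, a number 5 percentage points higher (within the scatter) from compound 2 to compound 1 and a number 5 percentage points higher (within the scatter) from compound 3 to compound 4, 0 percentage points apart, within the scatter of two such steps This agreement shows only that the change, in these two pairs, stayed within the scatter on both cores; it does not show that removing a methoxy group raises inhibition on either core, and two pairs at a single dose and time cannot establish a rule for the series, especially as in compound 4 the hydrogen enters ortho to a methoxy group and meta to a large group, a different place from the one in the earlier pair.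

The compounds shown leave open whether a chloro, hydroxyl or amine group at that aromatic carbon would give a step beyond the scatter. They also leave open how the oxime and the ketone compare on an otherwise unchanged core, and how the ethyl and allyl chains compare.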